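Replacing bromo with methyl in compound 3

This account rests on a few compounds, and the source may have more. Where it says the series, first, only, none or still open, it means among the compounds named here.

- compound 1 `O=C(/C=C/c1cccc(OCc2ccccc2)c1)c1ccc([N+](=O)[O-])cc1` gives 80900 nM
- compound 2 `O=C(/C=C/c1cccc(OCc2ccccc2)c1)c1ccc(Cl)cc1Cl` gives 19200 nM
- compound 3 `O=C(/C=C/c1cccc(OCc2ccccc2)c1)c1ccc(Br)cc1` gives 7400 nM

In a functional assay on BT-20 cells (Homo sapiens) for cytotoxicity, read by MTT assay, with a stated time of 68 h (on this read-out lower numbers stand for stronger inhibition and higher numbers for weaker inhibition), compound 3 has the lowest of the three numbers, 7400 nM. Compound 4 `Cc1ccc(C(=O)/C=C/c2cccc(OCc3ccccc3)c2)cc1` carries methyl in place of bromo on an aromatic carbon, para to a large group: methyl in place of bromo on an aromatic carbon. Among the measured compounds shown here, no measured step makes this exchange. The nearest evidence is an 11-fold lower number from compound 1 to compound 3 (1.04 log units; beyond the scatter), along with a 2.6-fold lower number from compound 2 to compound 3 (0.41 log units; beyond the scatter). Both steps end at the lowest number, so a small move back toward higher numbers is expected, perhaps no larger than the scatter. The expected step is a 1.6-fold higher number from compound 3 to compound 4 (0.21 log units; within the scatter). The estimate for compound 4 is 12000 nM, with an expected range from 5000 nM to 30000 nM.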

Compound 4, half-maximal inhibitory concentration: 61000 nM
Estimate against measurement, compound 4: 5.1-fold (0.71 log units) below; measured number above the stated range.
By their numbers in this assay, from the lowest: compound 3; then compound 2; then compounds 4 and 1 (each within the scatter of the next).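

Bromo and methyl each count one heavy atom, yet exchanging them at this place on the aromatic ring is a large move (an 8.2-fold higher number from compound 3 to compound 4 (0.92 log units; beyond the scatter)). The methyl compound also falls behind the 2,4-dichlorophenyl compound (a 3.2-fold higher number from compound 2 to compound 4 (0.50 log units; beyond the scatter)) and cannot be separated from the nitro compound (a 1.3-fold lower number from compound 1 to compound 4 (0.12 log units; within the scatter)), so of the groups shown, only bromo gives the low number of compound 3. Nothing measured on these compounds explains this result. Going by these compounds, whether the low number is special to bromo remains open, since a single chloro, an iodo or a methoxy at this place could fall on either side. An amine or a carboxylic acid there is equally undecided.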